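The source may report more compounds than this note shows. Statements on the series, on what has been measured and on what is new or still open speak of the compounds shown alone.

Three compounds share one core and differ only in the amine carried on it. Compound 1 `O=C(CCc1ccc(C(F)(F)F)cc1)Nc1ccc2nc(N3CCCCC3)ccc2c1` carries a piperidin-1-yl group, and in an assay on isolated protein for displacement of a labelled ligand from melanin-concentrating hormone receptor 1 (Homo sapiens) (a higher number here means a weaker inhibitor, a lower number a stronger inhibitor), compound 1 gives 12 nM. Compound 2 `CN(C)c1ccc2cc(NC(=O)CCc3ccc(C(F)(F)F)cc3)ccc2n1` carries a dimethylamino group instead, and compound 2 gives 13 nM. Compound 3 `O=C(CCc1ccc(C(F)(F)F)cc1)Nc1ccc2nc(N3CCC3)ccc2c1` carries an azetidin-1-yl group, and compound 3 gives 4 nM. Among these numbers compound 1 stands second highest: the step of a 1.1-fold higher number from compound 1 to compound 2 (0.03 log units; within the scatter) lies within the scatter, while the step of a 3.0-fold lower number from compound 1 to compound 3 (0.48 log units; beyond the scatter) goes beyond it, as does a 3.3-fold lower number from compound 2 to compound 3 (0.51 log units; beyond the scatter).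

The unmeasured compound 4 `O=C(CCc1ccc(C(F)(F)F)cc1)Nc1ccc2nc(N3CC4CCC3CC4)ccc2c1` alters the same group: a group of 8 heavy atoms (7 carbon, 1 nitrogen; 2 six-membered non-aromatic rings with 1 hetero atom each) in place of a group of 6 heavy atoms (5 carbon, 1 nitrogen; one six-membered non-aromatic ring with 1 hetero atom), on an aromatic carbon. The measured steps bear on this only loosely. The entering group is unlike anything measured, and the two groups that were compared with piperidin-1-yl gave either a number within the scatter or a lower one for the azetidin-1-yl group. For the measured compounds named here, no measured step shows what a larger group does here. The step of a 1.7-fold higher number from compound 1 to compound 4 (0.22 log units; within the scatter) is therefore expected to be small, within the scatter or slightly upward. Compound 4 is estimated at 20 nM, with a range from 7 nM to 60 nM.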

Compound 4, half-maximal inhibitory concentration: 3 nM
For compound 4 the middle estimate is 6.7-fold (0.82 log units) above the measured one, and the stated range ends above it.
By their numbers in this assay, from the lowest: compounds 4 and 3 (each within the scatter of the next); then compounds 1 and 2 (each within the scatter of the next).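

The place next to the ring nitrogen accepts a group larger than piperidin-1-yl, and in this assay the larger group of two six-membered non-aromatic rings gives a lower number than piperidin-1-yl (a 4.0-fold lower number from compound 1 to compound 4 (0.60 log units; beyond the scatter)) and than dimethylamino (a 4.3-fold lower number from compound 2 to compound 4 (0.64 log units; beyond the scatter)). This group and the much smaller azetidin-1-yl ring cannot be told apart (a 1.3-fold lower number from compound 3 to compound 4 (0.12 log units; within the scatter)), so across these four compounds the number does not simply rise or fall with the size of the amine. Nothing available explains why these two groups go together.

On these data alone, whether a pyrrolidin-1-yl or a morpholin-4-yl group would fall with compound 3 and compound 4 or with compound 1 and compound 2 stays open. So does whether the same order of amines would hold with a different chain on the amide.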